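Cytotoxicity of an isomer of compound 1

The compounds below may be only part of what the source reports. "The series", "measured", "known", "first", "only" and "open" are said of these compounds alone.

compound 1 `CC1(Cc2ccccc2)CC(S(=O)(=O)c2ccc(F)cc2)=C(c2ccc(/C(N)=N/O)cc2)O1`: 102000 nM
compound 2 `CC1(Cc2cccc(C(F)(F)F)c2)CC(S(=O)(=O)c2ccc(F)cc2)=C(c2ccc(/C(N)=N/O)cc2)O1`: 49800 nM
compound 3 `Cc1cccc(CC2(C)CC(S(=O)(=O)c3ccc(F)cc3)=C(c3ccc(/C(N)=N/O)cc3)O2)c1`: 112000 nM

In an ADME assay on cells (Peritoneal macrophage, Mus musculus, strain Balb/c) for cytotoxicity, read by resazurin assay, with a stated time of 72 h (a lower number here means that less compound is tolerated, a higher number that more compound is tolerated), compound 1 gives 102000 nM. The methyl analogue shows a 1.1-fold higher number from compound 1 to compound 3 (0.04 log units; within the scatter), so these two values cannot be told apart. The trifluoromethyl analogue shows a 2.0-fold lower number from compound 1 to compound 2 (0.31 log units; beyond the scatter), and replacing its trifluoromethyl with methyl gives a 2.2-fold higher number from compound 2 to compound 3 (0.35 log units; beyond the scatter).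

Compound 4 `CC1(Cc2ccccc2)CC(S(=O)(=O)c2ccc(F)cc2)=C(c2cccc(/C(N)=N/O)c2)O1` has the same atoms as compound 1, joined differently: a group of 10 heavy atoms (7 carbon, 2 nitrogen, 1 oxygen; one six-membered aromatic ring of carbon only) in place of a group of 10 heavy atoms (7 carbon, 2 nitrogen, 1 oxygen; one six-membered aromatic ring of carbon only), on a double-bonded ring carbon. The change lies on a double-bonded ring carbon, next to the ring oxygen. None of the three measured steps touches this place, as all of them alter the aromatic ring of the benzyl group. They offer only indirect guidance, and the largest of them is modest. No step beyond the scatter is therefore expected in this assay, though a direct precedent is lacking. The expected change is a 1.1-fold lower number from compound 1 to compound 4 (0.05 log units; within the scatter). Compound 4 is estimated at 90000 nM, with an expected range of 40000 nM to 200000 nM.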

Compound 4, half-maximal cytotoxic concentration: > 200000 nM
Compound 4 ended at the assay's limit (the forecaster's own chance of this, stated with the estimate: 15%); middle value at least 2.2-fold (0.34 log units) from the limit.
By their numbers in this assay, from the lowest: compound 2; then compounds 1 and 3 (each within the scatter of the next). At a limit, above all of these: compound 4.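

In this assay, compound 4 gives > 200000 nM, which is a limit of the assay and not a number. Joining the same atoms differently on the double-bonded ring carbon gives an at least 1.9-fold higher number from compound 1 to compound 4 (0.29 log units; that floor lies within the scatter), so this place can move the number upward, a direction that none of the changes on the benzyl group showed beyond the scatter, although the floor of this step alone does not establish a shift beyond the scatter. Compound 4 is the only compound shown that reaches this ceiling: the limit of > 200000 nM in this assay, at which 1 of the 4 values shown sits.

Going by these compounds, how far compound 4 lies past the limit stays unknown, as does whether the change would act in the same way alongside the trifluoromethyl or methyl groups of compound 2 and compound 3. The compounds shown also leave open what an amine or a carboxylic acid on this aromatic ring would do.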